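A few compounds are considered here, and "the series" means these few. Any claim that something is new, unique, unknown or untested is made for them only; others in the source may bear on it.

For the measured compounds named here, compound 3 `N#Cc1cccc(COc2ccc(-c3cc(CN4CCN(c5ccc(C(F)(F)F)cn5)CC4)no3)cc2)c1` is one of three compounds measured in a functional assay on Huh-7 cells (Homo sapiens) for antiproliferative activity, read by sulforhodamine B assay, with a stated time of 72 h; on this read-out higher numbers stand for weaker inhibition and lower numbers for stronger inhibition. Among the three numbers, compound 3 gives 1700 nM, the second highest. Compound 1 `N#Cc1cccc(COc2ccc(-c3cc(CN4CCN(Cc5ccc(C(F)(F)F)cc5)CC4)no3)cc2)c1` gives 100 nM, and compound 2 `N#Cc1cccc(COc2ccc(-c3cc(CN4CCN(c5ccc(C(F)(F)F)cc5)CC4)no3)cc2)c1` gives 2200 nM. The two large steps in this set, a 22-fold higher number from compound 1 to compound 2 (1.34 log units; beyond the scatter) and a 17-fold higher number from compound 1 to compound 3 (1.23 log units; beyond the scatter), both follow the exchange of a 4-(trifluoromethyl)benzyl group for an aromatic ring placed directly on the ring nitrogen. The step between the two directly attached rings, a 1.3-fold lower number from compound 2 to compound 3 (0.11 log units; within the scatter), lies within the scatter.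

Compound 4 `N#Cc1cccc(COc2ccc(-c3cc(CN4CCN(c5ccc(F)cc5)CC4)no3)cc2)c1` differs from compound 3 by 4-fluorophenyl in place of 5-(trifluoromethyl)pyridin-2-yl on an amine nitrogen in a ring. This change keeps an aromatic ring directly on the ring nitrogen, so the large steps from compound 1 do not bear on it; the step from compound 2 to compound 3 is the one that does, and it was small. For compound 4 the expected step is therefore a 1.2-fold higher number from compound 3 to compound 4 (0.07 log units; within the scatter), none beyond the scatter in either direction. Compound 4 is estimated to give 2000 nM in this assay, with a range from 700 nM to 6000 nM.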

Compound 4, half-maximal inhibitory concentration: 1500 nM
Beside the measured number, compound 4's estimate is 1.3-fold (0.12 log units) above it, and the stated range covers the measured number.
By their numbers in this assay, from the lowest: compound 1; then compounds 4, 3 and 2 (each within the scatter of the next).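

Compound 4 carries neither the trifluoromethyl group nor the pyridine nitrogen, yet both comparisons that involve it stay within the scatter: the exchange of the whole ring (a 1.1-fold lower number from compound 3 to compound 4 (0.05 log units; within the scatter)) and the exchange of fluoro for trifluoromethyl on an aromatic carbon (a 1.5-fold lower number from compound 2 to compound 4 (0.17 log units; within the scatter)). So on this ring nitrogen, neither that hetero atom nor the larger substituent shows a readable effect across these three directly attached rings. For the compounds shown here, the large gap to the benzyl compound appears a third time with a different ring substituent (a 15-fold higher number from compound 1 to compound 4 (1.18 log units; beyond the scatter)), and compound 1 remains the only compound apart from the others.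

The compounds shown leave open whether a 4-fluorobenzyl group or a longer chain such as 2-phenylethyl on this nitrogen would fall with compound 1 or with the directly attached rings. Nothing available here explains the gap between the benzyl compound and these rings.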